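The source may report more compounds than this note shows. Statements on the series, on what has been measured and on what is new or still open speak of the compounds shown alone.

compound 1 `CC(C)CN(Cc1ccc(N2CCN(NS(C)(=O)=O)CC2)cc1)S(=O)(=O)Cc1ccccc1` — <= 1000 nM (a limit)
compound 2 `CC(C)CN(Cc1ccc(N2CCN(CS(C)(=O)=O)CC2)cc1)S(=O)(=O)Cc1ccccc1` — <= 1000 nM (a limit)
compound 3 `COC1CCN(c2ccc(CN(CC(C)C)S(=O)(=O)Cc3ccccc3)cc2)CC1` — <= 1000 nM (a limit)

In a physicochemical assay for solubility, in phosphate buffer, measured as kinetic solubility, with a stated time of 24 h, at pH 7.4 (a higher number here means a more soluble compound, a lower number a less soluble compound), compound 2 gives <= 1000 nM, which is a limit of the assay and not a number. Compound 1 and compound 3 sit at the same limit: the limit of <= 1000 nM in this assay, at which 3 of the 3 values shown sit. Hence the steps a step that the two limits leave unreadable from compound 1 to compound 2, a step that the two limits leave unreadable from compound 1 to compound 3 and a step that the two limits leave unreadable from compound 2 to compound 3 cannot be read in size or direction. Compound 4 `CC(C)CN(Cc1ccc(N2CCC(C#N)CC2)cc1)S(=O)(=O)Cc1ccccc1` differs from compound 2 in one place: 4-cyanopiperidin-1-yl in place of 4-((methylsulfonyl)methyl)piperazin-1-yl on an aromatic carbon. Among the measured compounds shown here, no measured step resolves a change of this kind, so the data give no direction for it. Compound 4 is expected to remain near the limit, estimated at 600 nM (range 100 nM to 3000 nM). The step that the limit leaves unreadable from compound 2 to compound 4 is therefore the expected outcome, most likely again reported only as a limit.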

Compound 4, solubility: <= 1000 nM
Compound 4 ended at the assay's limit (the forecaster's own chance of this, stated with the estimate: 70%); the middle value lies beyond the limit too.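

Compound 4 gives <= 1000 nM as a limit and not a number, so its steps from compound 1, compound 2 and compound 3 cannot be read: the limit of <= 1000 nM in this assay, at which 4 of the 4 values shown sit. The compounds shown leave open whether any of them differs from another in solubility.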